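The source may report more compounds than this note shows. Statements on the series, on what has been measured and on what is new or still open speak of the compounds shown alone.

Measured so far in an in vitro ADME assay on microsomes from liver (Homo sapiens) for metabolic stability; on this read-out lower numbers stand for slow clearance and higher numbers for fast clearance:

Compound 1 `CC(C)Nc1nccc(-c2c[nH]nc2C2CCCCO2)n1`: 0.021 mL/min/kg
Compound 2 `C[C@H](CC(=O)O)Nc1nccc(-c2c[nH]nc2-c2ccc(Cl)cc2)n1`: < 0.006 mL/min/kg
Compound 3 `c1cc(-c2c[nH]nc2C2CCCOC2)nc(NC2CCCC2)n1`: 0.089 mL/min/kg

Only two of these results are actual numbers. Compound 2 gives a limit of the assay, < 0.006 mL/min/kg, and not a number. Of the other two, compound 1 has the lower clearance, 0.021 mL/min/kg, while compound 3 gives 0.089 mL/min/kg, a gap beyond the usual scatter of repeated measurements.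

The next compound to be tested is compound 4 `CC(C)Nc1nccc(-c2c[nH]nc2C2CCCNC2)n1`. It carries piperidin-3-yl in place of oxan-2-yl on an aromatic carbon of the core of compound 1: piperidin-3-yl in place of oxan-2-yl on an aromatic carbon. Among the compounds with values here, no two measured compounds differ in just one place, so the data offer no direct guide to this swap. The starting point is therefore compound 1 with 0.021 mL/min/kg, and no change beyond the scatter is expected in this assay. The estimated step of a 1.2-fold lower number from compound 1 to compound 4 (0.07 log units; within the scatter) is small. For compound 4 the estimated clearance is 0.018 mL/min/kg, with an expected range of 0.007 mL/min/kg to 0.06 mL/min/kg.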

Compound 4, clearance: 0.014 mL/min/kg
Compound 4: the middle estimate sits 1.3-fold (0.11 log units) above what was measured; the measured number falls inside the stated range.
By their numbers in this assay, from the lowest: compounds 4 and 1 (each within the scatter of the next); then compound 3. At a limit, below all of these: compound 2.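

In this assay, piperidin-3-yl in place of oxan-2-yl gives a 1.5-fold lower number from compound 1 to compound 4 (0.18 log units; within the scatter), so the data show no change beyond the scatter when this ring's oxygen gives way to a nitrogen with its added hydrogen-bond donor. Within the data shown here, no earlier pair differed in one place, so this is the first direct reading for any change on this aromatic carbon of the five-membered ring. Compound 2 differs from compound 4 in more than one place and gives only a limit of the assay, not a number: the limit of < 0.006 mL/min/kg in this assay, at which 1 of the 4 values shown sits.

Still open, from the compounds shown here alone, is whether cyclohexyl, a ring with no hetero atom, or an open chain such as n-butyl would give a similar clearance on this carbon. Going by these compounds, it is also open whether this swap would read the same with a different group on the core's amine, such as the cyclopentyl of compound 3.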